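This account rests on a few compounds, and the source may have more. Where it says the series, first, only, none or still open, it means among the compounds named here.

Values measured in a functional assay on HL-60 cells (Homo sapiens) for cytotoxicity, read by WST assay, with a stated time of 48 h; on this read-out higher numbers stand for an effect only at larger amounts of compound and lower numbers for an effect already at smaller amounts:

- Compound 1 `COc1ccccc1C[C@H]1COC(=O)[C@@H]1Cc1ccc(Cl)c(Cl)c1`: 14000 nM
- Compound 2 `O=C1OC[C@H](Cc2ccc(F)cc2)[C@H]1Cc1ccc(Cl)c(Cl)c1`: 14000 nM

Compound 2 stands level with compound 1 on these numbers, so neither can be ranked above the other. Compound 3 `Cc1ccc(C[C@H]2COC(=O)[C@@H]2Cc2ccc(Cl)c(Cl)c2)cc1C` has not yet been measured. It differs from compound 2 as follows: 3,4-dimethylphenyl in place of 4-fluorophenyl on a saturated chain carbon bound to a saturated ring carbon. In words, 3,4-dimethylphenyl stands in place of 4-fluorophenyl on a saturated chain carbon bound to a saturated ring carbon.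

Within the data shown here, only one measured step bears on this change, an exchange of groups at that same place: no change at the digits printed from compound 1 to compound 2 (within the scatter). That single step is thin evidence, but it gives no reason to expect a shift in either direction in this assay beyond the usual scatter. The expected step is no change at the digits printed from compound 2 to compound 3 (within the scatter). For compound 3 the estimate is 14000 nM, with an expected range from 6000 nM to 32000 nM.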

Compound 3, half-maximal effective concentration: 16000 nM
Compound 3: the middle estimate sits 1.1-fold (0.06 log units) below what was measured; measured number inside the range.
By their numbers in this assay, from the lowest: compounds 1, 2 and 3 (each within the scatter of the next).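

In this assay, 3,4-dimethylphenyl in place of 4-fluorophenyl gives a 1.1-fold higher number from compound 2 to compound 3 (0.06 log units; within the scatter) and 3,4-dimethylphenyl in place of 2-methoxyphenyl gives a 1.1-fold higher number from compound 1 to compound 3 (0.06 log units; within the scatter) on a saturated chain carbon bound to a saturated ring carbon. This place has now taken three differently substituted phenyl groups, including one that carries two methyl groups and neither fluorine nor methoxy, and the read-out has stayed within the scatter across all three. Nothing available accounts for this sameness of the numbers. All three compounds keep a phenyl ring at this place on the same core, so the compounds shown say nothing about an amine, a carboxylic acid or a longer chain there. They also leave open whether a change elsewhere on the shared core would move the number.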